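Replacing a Trifluoromethylphenyl Group on the Shared Core

A few compounds are considered here, and "the series" means these few. Any claim that something is new, unique, unknown or untested is made for them only; others in the source may bear on it.

Of the compounds shown here, two have been measured in a functional assay on BGC-823 cells (Homo sapiens) for antiproliferative activity, read by MTT assay, tested at 5 uM; on this read-out higher numbers stand for a stronger effect at the one concentration tested and lower numbers for a weaker effect. Compound 1, `COc1cc(C2=NN(C(C)=O)C(c3ccccc3C(F)(F)F)O2)cc(OC)c1OC`, gives 34.8%, the higher of the two numbers. Compound 2, `COc1cc(C(=O)N/N=C/c2ccc(Cl)c([N+](=O)[O-])c2)cc(OC)c1OC`, gives 2.3% in this assay, a gap below compound 1 that lies beyond the scatter. Among the measured compounds shown here, the two differ in more than one place, so this gap cannot be tied to a single change, and no pair of measured compounds differing in one place is available to show what any one change does. Compound 3, `COc1cc(C2=NN(C(C)=O)C(c3cccc(OC)c3OC)O2)cc(OC)c1OC`, has not yet been measured; it is built from compound 1 by one change: 2,3-dimethoxyphenyl in place of 2-(trifluoromethyl)phenyl on a saturated ring carbon. Nothing measured tells how this change affects the read-out, so the forecast rests on compound 1 alone and carries a wide range. The expected step is a number 4.8 percentage points lower from compound 1 to compound 3 (within the scatter), small enough to fall within or close to the scatter, with no clear direction. Compound 3 is therefore estimated to give about 30%, with a range from 10% to 52%.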

Compound 3, a percentage reported as inhibition, at one concentration (the size of the read-out at that concentration, not a potency): 17.5%
The estimate for compound 3 lay 12.5 percentage points above the measured number; the range from low to high includes it.
By their numbers in this assay, from the lowest: compound 2; then compound 3; then compound 1.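

Among the compounds shown here, the comparison of compound 1 with compound 3 is the first on the shared core that differs in one place only, and it shows that the group on this saturated ring carbon affects the read-out in this assay. Putting 2,3-dimethoxyphenyl in place of 2-(trifluoromethyl)phenyl gives a number 17.3 percentage points lower from compound 1 to compound 3 (beyond the scatter), so a change beyond the scatter can now be tied to this one position, which the gap between compound 1 and compound 2 could not do. No measurement of any property of these two groups bears on this result, and what lies behind the step remains unexplained.

On these data alone, with only these two groups compared at this carbon, it remains open whether a plain phenyl, a 2-chlorophenyl or a 2-aminophenyl group would give a number nearer that of compound 1 or that of compound 3. As far as these compounds go, it is also open whether the same change would have a similar effect if the acetyl group on the shared core gave way to a longer chain such as propanoyl.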